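This account rests on a few compounds, and the source may have more. Where it says the series, first, only, none or still open, it means among the compounds named here.

Measured so far: compound 1 `O=C(Nc1ccc(F)cc1)N1CCN(c2ccnc(Cl)n2)CC1` gives 1140 nM in an assay on isolated protein for antagonist activity at transient receptor potential cation channel subfamily V member 1 (Homo sapiens) (on this read-out higher numbers stand for weaker inhibition and lower numbers for stronger inhibition), and compound 2 `O=C(Nc1ccc(C(F)(F)F)cc1)N1CCN(c2ccnc(Cl)n2)CC1` gives 874 nM.

Compound 1 stands as the higher of the two numbers, with compound 2 nearest; the step of a 1.3-fold lower number from compound 1 to compound 2 (0.12 log units; within the scatter) lies within the scatter. Compound 3 `COc1ccccc1NC(=O)N1CCN(c2ccnc(Cl)n2)CC1` differs from compound 1 by 2-methoxyphenyl in place of 4-fluorophenyl on an amide-type nitrogen. Within the data shown here, the one measured step, from compound 1 to compound 2, changed a group on the same phenyl ring without a shift beyond the scatter, so for compound 3 no step beyond the scatter is expected in this assay. Compound 3 is therefore estimated at 1200 nM, a range of 400 nM to 3600 nM, and an expected step of a 1.1-fold higher number from compound 1 to compound 3 (0.02 log units; within the scatter).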

Compound 3, half-maximal inhibitory concentration: 9420 nM
Compound 3: middle estimate off by 7.9-fold (0.89 log units), on the low side, and the stated range ends below it.
By their numbers in this assay, from the lowest: compounds 2 and 1 (each within the scatter of the next); then compound 3.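

In this assay, the group on this amide-type nitrogen can shift the number beyond the scatter: 2-methoxyphenyl in place of 4-fluorophenyl gives an 8.3-fold higher number from compound 1 to compound 3 (0.92 log units; beyond the scatter), whereas trifluoromethyl in place of fluoro gave only a 1.3-fold lower number from compound 1 to compound 2 (0.12 log units; within the scatter). Thus, the small effect of the earlier change does not hold for every change to this aryl group. No available evidence accounts for the weaker inhibition of compound 3. The compounds shown leave open whether the methoxy group itself or its place on the ring drives the step, a question that 4-methoxyphenyl and 2-fluorophenyl would separate.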